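Clearance notes: phenoxy to methyl(1-methyl-1H-pyrazol-3-yl)amino swap

The compounds below may be only part of what the source reports. "The series", "measured", "known", "first", "only" and "open" are said of these compounds alone.

Measured so far:
- compound 1, `CN(C)C(=O)c1cc(-c2cnc(NCc3c(F)ccc4c3CCO4)c3cn[nH]c(=O)c23)n(C)n1`, 21 mL.min-1.g-1
- compound 2, `Fc1ccc2c(c1CNc1ncc(Oc3ccccc3)c3nncn13)CCO2`, 18 mL.min-1.g-1
- compound 3, `Cc1ncccc1-c1cnc(NCc2c(F)ccc3c2CCO3)c2n[nH]c(=O)n12`, 8 mL.min-1.g-1

The three compounds share the fused core and the same benzylic amine side group and were run in an ADME assay on microsomes from liver (Homo sapiens) for metabolic stability, read by LC-MS, using NADPH, with stated times of 5 min and 30 min, tested at 1 uM; a higher number here means faster removal of the compound, a lower number slower removal. Compound 2 gives 18 mL.min-1.g-1, which sits second highest of the three. Its nearest neighbour is compound 1 with 21 mL.min-1.g-1; that gap is within the scatter, so no order between the two can be claimed. Compound 3, at 8 mL.min-1.g-1, is the furthest, and that gap lies beyond the scatter. Among the measured compounds shown here, no pair of measured compounds differs in a single place, so no step size has been isolated from the data at hand.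

Compound 4, `CN(c1ccn(C)n1)c1cnc(NCc2c(F)ccc3c2CCO3)n2cnnc12`, is the next candidate and is related to compound 2 by one change: methyl(1-methyl-1H-pyrazol-3-yl)amino in place of phenoxy on an aromatic carbon.

For the measured compounds named here, with no isolated step to lean on, the size of the step from compound 2 to compound 4 is uncertain; a modest move is expected, if anything towards a lower number, but a result within the scatter of compound 2 is as plausible. The estimated change is a 1.3-fold lower number from compound 2 to compound 4 (0.11 log units; within the scatter). Compound 4 is expected to give 14 mL.min-1.g-1, in the range 6 mL.min-1.g-1 to 33 mL.min-1.g-1.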

Compound 4, intrinsic clearance in microsomes: 11 mL.min-1.g-1
Compound 4: middle estimate off by 1.3-fold (0.10 log units), on the high side; low and high end bracket the measured number.
By their numbers in this assay, from the lowest: compounds 3, 4, 2 and 1 (each within the scatter of the next, the first and the last beyond it).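

In this assay, among the compounds shown here, replacing phenoxy with methyl(1-methyl-1H-pyrazol-3-yl)amino gives a 1.6-fold lower number from compound 2 to compound 4 (0.21 log units; within the scatter), the first step that isolates a change in one place. This position, on an aromatic carbon of the six-membered aromatic ring with 2 nitrogen and para to a large group, therefore accepts a five-membered aromatic ring with 2 hetero atoms in place of a six-membered aromatic ring of carbon only, with a step that cannot be told from repeat-measurement noise. No measured information is available to explain the size of this step.

A single step at one position does not show whether the numbers here can be moved beyond the scatter, and a simple dimethylamino group, a morpholine ring or the secondary amine without the methyl on the linking nitrogen would test that more widely. Going by these compounds, whether the same swap gives a similar step on the core of compound 1 or the core of compound 3 also remains open.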